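The source may hold more compounds than are shown below. What is called first, only, known or untested is meant among the compounds shown, and "the series" means these compounds.

Among the compounds with values here, in a functional assay on DU-145 cells (Homo sapiens) for cytotoxicity, read by sulforhodamine B assay, with a stated time of 48 h (on this read-out lower numbers stand for stronger inhibition and higher numbers for weaker inhibition), three compounds sharing one core have numbers so far. Compound 1 `C[C@H]1CC[C@@H]2[C@@H](OC(=O)[C@]23CC(c2c(Cl)cccc2Cl)=NO3)[C@]2(C)C(=O)C=C[C@@]12O` gives 38000 nM and compound 2 `C[C@H]1CC[C@@H]2[C@@H](OC(=O)[C@]23CC(c2ccc(Cl)cc2)=NO3)[C@]2(C)C(=O)C=C[C@@]12O` gives 43000 nM, and a 1.1-fold higher number from compound 1 to compound 2 (0.05 log units; within the scatter) shows that these two cannot be told apart. Compound 3 `C[C@H]1CC[C@@H]2[C@@H](OC(=O)[C@]23CC(c2ccc(O)cc2)=NO3)[C@]2(C)C(=O)C=C[C@@]12O` gives 93000 nM, the highest number of the three and so the weakest inhibition.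

Compound 4 `COc1ccc(C2=NO[C@]3(C2)C(=O)O[C@@H]2[C@H]3CC[C@H](C)[C@]3(O)C=CC(=O)[C@@]23C)cc1OC` has not yet been measured. It carries 3,4-dimethoxyphenyl in place of the 4-hydroxyphenyl of compound 3, on a carbon with a double bond to nitrogen: 3,4-dimethoxyphenyl in place of 4-hydroxyphenyl on a carbon with a double bond to nitrogen.

Like compound 1 and compound 2, compound 4 has no hydroxy group on this aromatic ring. Within the data shown here, the steps that bear on the change are a 2.4-fold higher number from compound 1 to compound 3 (0.39 log units; beyond the scatter) and a 2.2-fold higher number from compound 2 to compound 3 (0.34 log units; beyond the scatter), both modest. Read in reverse, they point to a modest fall in the number in this assay, although no dimethoxyphenyl compound has been measured. The expected step is a 2.1-fold lower number from compound 3 to compound 4 (0.32 log units; beyond the scatter). For compound 4, the estimated value is 45000 nM, with an expected range from 18000 nM to 100000 nM.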

Compound 4, half-maximal inhibitory concentration: 84000 nM
Estimate against measurement, compound 4: 1.9-fold (0.27 log units) below, and the stated range covers the measured number.
By their numbers in this assay, from the lowest: compounds 1, 2, 4 and 3 (each within the scatter of the next, the first and the last beyond it).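

Losing the hydroxy group from this aromatic ring does not by itself lower the number in this assay, since 3,4-dimethoxyphenyl, which has no hydroxy group, cannot be told apart from 4-hydroxyphenyl (a 1.1-fold lower number from compound 3 to compound 4 (0.04 log units; within the scatter)). Compound 4 also cannot be told apart from the 4-chlorophenyl compound (a 2.0-fold higher number from compound 2 to compound 4 (0.29 log units; within the scatter)) and is separated only from the 2,6-dichlorophenyl compound (a 2.2-fold higher number from compound 1 to compound 4 (0.34 log units; beyond the scatter)), so adding two methoxy groups to the ring gives no clear change from the chlorinated compounds beyond that modest gap. Nothing measured here explains why these rings differ or match.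

Every group shown at this position is a substituted phenyl ring. As far as these compounds go, whether an amine or a carboxylic acid on that ring, or a longer alkyl chain in its place, would shift the number further remains open.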